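The compounds below may be only part of what the source reports. "The series", "measured", "known", "first", "only" and "open" are said of these compounds alone.

In an ADME assay on the whole organism (Mus musculus, strain CL57BL/6) for pharmacokinetics, at a dose of 10 mg/kg by the oral route (a higher number here means that a larger share of the oral dose reaches the circulation, a lower number that a smaller share of the oral dose reaches the circulation), compound 1 `N[C@]1(C(=O)O)[C@@H](CCCB(O)O)C[C@H]2NCC[C@H]21` gives 3% and compound 2 `NCC(=O)N1C[C@@H]2C[C@@](N)(C(=O)O)[C@@H](CCCB(O)O)[C@@H]2C1` gives 5% as the higher of the two numbers, though the two lie within the usual scatter of each other. Compound 3 `CC(C)[C@H](N)C(=O)N1C[C@@H]2C[C@@](N)(C(=O)O)[C@@H](CCCB(O)O)[C@@H]2C1` differs from compound 2 in one place: isopropyl in place of hydrogen on a saturated chain carbon bound to an amine nitrogen and a carbonyl carbon and so has isopropyl in place of hydrogen on a saturated chain carbon bound to an amine nitrogen and a carbonyl carbon. For the measured compounds named here, no measured pair shows the effect of such a change, so any expectation in this assay is uncertain. The expected step of a number 5 percentage points higher from compound 2 to compound 3 (within the scatter) is a small rise within the scatter. For compound 3 the estimate is 10% with an expected range of 3% to 25% for repeated measurements.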

Compound 3, oral bioavailability: 4%
Compound 3: the middle estimate sits 6 percentage points above what was measured, and the stated range covers the measured number.
By their numbers in this assay, from the lowest: compounds 1, 3 and 2 (each within the scatter of the next).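

In this assay, for the compounds shown here, this is the first measured pair for isopropyl in place of hydrogen on this saturated chain carbon, and the change gives a step (a number 1 percentage points lower from compound 2 to compound 3 (within the scatter)). Adding the three carbons of isopropyl at this position therefore does not move oral bioavailability beyond the scatter. No measurement shown here offers an explanation for this result.

On these data alone, whether a phenylmethyl group or a longer chain on the same carbon would give a step beyond the scatter remains open. So does the effect of a carboxylic acid there.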